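Piperazine nitrogen substituent: isopropyl to cyclopropyl

The source may hold more compounds than are shown below. What is called first, only, known or untested is meant among the compounds shown, and "the series" means these compounds.

Measured compounds:
compound 1, `c1cnc(CN(CCCN2CCNCC2)[C@H]2CCCc3cccnc32)nc1`, 31 nm/s
compound 2, `c1cnc2c(c1)CCC[C@@H]2N(CCCN1CCNCC1)Cc1nc2ccccc2s1`, "not determined" (no result reported)
compound 3, `CC(C)N1CCN(CCCN(C[C@H]2Cc3ccccc3CN2)[C@H]2CCCc3cccnc32)CC1`, 344 nm/s

In an ADME assay for permeability, using PAMPA, with a stated time of 4 h, at pH 7.4 (on this read-out higher numbers stand for higher permeability and lower numbers for lower permeability), compound 1 gives 31 nm/s. In this assay compound 2 gives "not determined" (no result reported), so no number is available for it. In this assay compound 3 gives 344 nm/s, the higher of the two numbers available; the gap to compound 1 lies beyond the scatter of repeated measurements.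

Compound 4, `c1ccc2c(c1)CN[C@@H](CN(CCCN1CCN(C3CC3)CC1)[C@H]1CCCc3cccnc31)C2`, is still to be measured in this assay. It differs from compound 3 in one place: cyclopropyl in place of isopropyl on an amine nitrogen in a ring. Cyclopropyl replaces isopropyl on an amine nitrogen in a ring, the ring being a six-membered non-aromatic ring with two nitrogens. Going by the values given here, no step of this kind between measured compounds exists, so the expectation rests on compound 3 alone. The step of a 1.2-fold higher number from compound 3 to compound 4 (0.07 log units; within the scatter) is expected to be small, probably within the scatter, if anything slightly upward. Compound 4 is therefore expected to give about 400 nm/s in this assay, with a range from 200 nm/s to 800 nm/s.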

Compound 4, apparent permeability: 505 nm/s
Compound 4: middle estimate off by 1.3-fold (0.10 log units), on the low side; the measured number falls inside the stated range.
By their numbers in this assay, from the lowest: compound 1; then compounds 3 and 4 (each within the scatter of the next).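

In this assay, the step from isopropyl to cyclopropyl on the amine nitrogen of the six-membered non-aromatic ring with two nitrogens reads a 1.5-fold higher number from compound 3 to compound 4 (0.17 log units; within the scatter), so the two groups cannot be told apart at this position on this read-out. Both groups have 3 heavy atoms, and adding the three-membered ring leaves the number within the scatter, which means the high value of compound 3 does not depend on isopropyl alone in this series. No measurement shown gives a cause for this result.

Open, as far as these compounds go, is how a longer chain or a carboxylic acid on this nitrogen would read in this assay. Also open, from the compounds shown here alone, is whether the same exchange would read alike on the core of compound 1, since this single step rests on one core only.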